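Halogen change in a three-compound cytotoxicity series

The source may report more compounds than this note shows. Statements on the series, on what has been measured and on what is new or still open speak of the compounds shown alone.

Measured so far in a functional assay on MOLT-4 cells (Homo sapiens) for cytotoxicity, with a stated time of 72 h; a higher number here means a weaker inhibitor, a lower number a stronger inhibitor:
compound 1, `O=C1/C(=C/c2ccc(F)cc2)CCC/C1=C\c1cccc([N+](=O)[O-])c1`, 5120 nM
compound 2, `O=C1/C(=C/c2ccc(F)cc2)CCC/C1=C\c1ccc([N+](=O)[O-])cc1`, 17100 nM
compound 3, `O=C1/C(=C/c2ccc(Cl)cc2)CCC/C1=C\c1ccc([N+](=O)[O-])cc1`, 9120 nM

Compound 1 and compound 2 share the same atoms joined differently; the difference between the two cores is not broken down here. Compound 2 and compound 3 differ by one change, (chloro in place of fluoro on an aromatic carbon), which gave a 1.9-fold lower number from compound 2 to compound 3 (0.27 log units; within the scatter).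

Compound 4, `O=C1/C(=C/c2ccc(Cl)cc2)CCC/C1=C\c1cccc([N+](=O)[O-])c1`, is not yet measured. It differs from compound 1 by chloro in place of fluoro on an aromatic carbon, the same change as from compound 2 to compound 3, with the same surroundings at the place of change. Compound 1 stands at the lowest number of the three measured compounds, though its gap to compound 3 is within the scatter and only its gap to compound 2 lies beyond it.

The expected step for compound 4 in this assay is a 1.6-fold lower number from compound 1 to compound 4 (0.19 log units; within the scatter), resting on the step of the same change from compound 2 to compound 3 being a 1.9-fold lower number from compound 2 to compound 3 (0.27 log units; within the scatter). Compound 4 is therefore estimated at 3300 nM, with a range from 1400 nM to 8000 nM.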

Compound 4, half-maximal inhibitory concentration: 2020 nM
Beside the measured number, compound 4's estimate is 1.6-fold (0.21 log units) above it; the measured number falls inside the stated range.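

In this assay, chloro in place of fluoro on the core of compound 1 gives a 2.5-fold lower number from compound 1 to compound 4 (0.40 log units; beyond the scatter). Set beside the earlier step, the change carries from one core to the other with no difference that can be told apart: the same change on two cores in this assay, a 1.9-fold lower number (0.27 log units; within the scatter) from compound 2 to compound 3 and a 2.5-fold lower number (0.40 log units; beyond the scatter) from compound 1 to compound 4, 1.4-fold (0.13 log units) apart, within the scatter of two such steps. This agreement rests on two pairs only, one of which lies within the scatter on its own, so it supports carrying the change between these two cores but shows no general rule for the series and gives no reason for the step.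

Among the compounds shown, only fluoro and chloro stand at the place of change, so it remains open how bromo or a methyl group there would compare. Also open, going by these compounds, is whether the step would hold on a core in which the nitro group gives way to an amine or a carboxylic acid.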